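This account rests on a few compounds, and the source may have more. Where it says the series, first, only, none or still open, it means among the compounds named here.

Compound 1 `CCCCNC(=O)OC/C=C(\C)C1=CC(=O)C(C)(C)O1`: in a functional assay on MOLT-4F cells (Homo sapiens) for inhibition (a lower number here means a stronger inhibitor, a higher number a weaker inhibitor), compound 1 gives 5.3 ug/mL.
Compound 2 `C/C(=C\COC(=O)NCc1ccccc1)C1=CC(=O)C(C)(C)O1`: in this assay compound 2 gives 6 ug/mL.

These two carbamates share one core and differ only in the group on the saturated chain carbon bound to the amide-type nitrogen. The two numbers lie within the scatter of each other: from compound 1 to compound 2 the change is a 1.1-fold higher number from compound 1 to compound 2 (0.05 log units; within the scatter). Compound 2 therefore stands alongside compound 1, with nothing to separate them.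

Compound 3 `C/C(=C\COC(=O)Nc1ccccc1)C1=CC(=O)C(C)(C)O1` is not yet measured. Relative to compound 2, it carries phenyl in place of benzyl on an amide-type nitrogen. Among the compounds with values here, the only measured step, phenyl in place of propyl on a saturated chain carbon bound to the amide-type nitrogen, was a 1.1-fold higher number from compound 1 to compound 2 (0.05 log units; within the scatter) and so within the scatter. Within the data shown here, it bears on the new step only loosely, since the step to compound 3 removes the saturated chain carbon and sets the aromatic ring directly on the nitrogen; no measured pair covers such a change. Among the measured compounds shown here, with a flat response to the one change that is known, compound 3 is expected to show no change at the digits printed from compound 2 to compound 3 (within the scatter) in this assay, that is, no step beyond the scatter. Compound 3 is accordingly estimated at 6 ug/mL, within the range 2.5 ug/mL to 14 ug/mL, the range widened because the change is of an unmeasured kind.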

Compound 3, half-maximal inhibitory concentration: > 200 ug/mL
Compound 3: only a limit was reported; the forecaster's own chance of this, stated with the estimate: 5%; at least 33-fold (1.52 log units) between middle value and limit.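

The reading for compound 3 is a limit and not a number: the limit of > 200 ug/mL in this assay, at which 1 of the 3 values shown sits. Even so, the group on the amide-type nitrogen proves far from indifferent in this assay: phenyl in place of benzyl gives an at least 33-fold higher number from compound 2 to compound 3 (1.52 log units; beyond the scatter), and phenyl in place of butyl gives an at least 37-fold higher number from compound 1 to compound 3 (1.57 log units; beyond the scatter). Compound 1 and compound 2 both hold a saturated chain carbon on the nitrogen and lie within the scatter of each other, whereas compound 3, with the aromatic ring set directly on the nitrogen, is the one that departs, so the flat response seen earlier holds only for that pair.

The compounds shown cannot separate the loss of the saturated chain carbon from the presence of an aromatic ring directly on the nitrogen, since the two go together in compound 3. A cyclohexyl group on the nitrogen would bear on that question, and a phenethyl group would show whether the tolerance seen with benzyl extends to a longer link to the ring.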